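Anilide series: nitro in place of chloro on the anilide ring

This account rests on a few compounds, and the source may have more. Where it says the series, first, only, none or still open, it means among the compounds named here.

The acid compound 1 `COc1cc2c(cc1OC)C(CC(=O)O)CC2` gives 20.4% in a functional assay on the whole organism (strain Wistar) for inhibition, with Rattus norvegicus as the target, read by paw edema, with a stated time of 6 h, at a dose of 100 mg/kg; on this read-out higher numbers stand for more inhibition at the one dose given (going by the name of the read-out) and lower numbers for less inhibition. Its anilides, compound 2 `COc1cc2c(cc1OC)C(CC(=O)Nc1cccc(Cl)c1)CC2` at 38.9% and compound 3 `COc1cc2c(cc1OC)C(CC(=O)Nc1ccc(Cl)cc1)CC2` at 61.1%, score higher: a number 18.5 percentage points higher from compound 1 to compound 2 (beyond the scatter) and a number 40.7 percentage points higher from compound 1 to compound 3 (beyond the scatter). Compound 3 stands highest of the three, with a number 22.2 percentage points higher from compound 2 to compound 3 (beyond the scatter) separating it from its nearest neighbour. Compound 4 `COc1cc2c(cc1OC)C(CC(=O)Nc1ccc([N+](=O)[O-])cc1)CC2` differs from compound 3 as nitro in place of chloro on an aromatic carbon. Among the compounds with values here, no measured step exchanges one substituent for another on an aromatic carbon of the anilide ring; the step from compound 2 to compound 3 shows only that the substituent pattern on that ring moves the read-out beyond the scatter. The expected step is therefore uncertain and set modest downward, a number 11.1 percentage points lower from compound 3 to compound 4 (beyond the scatter). Compound 4 is estimated at 50%, between 30% and 70%.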

Compound 4, a percentage reported as inhibition, in the whole organism at one dose (the size of the read-out at that dose, not a potency): 37%
Compound 4: middle estimate off by 13 percentage points, on the high side; the measured number falls inside the stated range.
By their numbers in this assay, from the lowest: compound 1; then compounds 4 and 2 (each within the scatter of the next); then compound 3.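

Nitro in place of chloro on the aromatic carbon para to a large group gives, in this assay, a number 24.1 percentage points lower from compound 3 to compound 4 (beyond the scatter), a kind of exchange that no earlier step covers. With the position held fixed, the identity of the substituent moves the read-out beyond the scatter, so the substituent pattern alone does not set the result, and chloro reads higher than nitro here. Nothing measured here explains this step.

Open, on these data alone, is how other groups at this position would read, such as fluoro, methoxy or an amine. Also open, as far as these compounds go, is whether a nitro group in the chloro position of compound 2 would give a comparable step.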